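Dimethoxybenzyl analogue of a chloropurine: expected to stay inactive

This account rests on a few compounds, and the source may have more. Where it says the series, first, only, none or still open, it means among the compounds named here.

Compound 1 `COc1ccc(Cn2cnc3c(N(C)c4ccc(OC)cc4)ncnc32)cc1` in a functional assay on K562 cells (Homo sapiens) for antiproliferative activity, read by MTT assay, with a stated time of 48 h (a lower number here means a stronger inhibitor of growth, a higher number a weaker inhibitor of growth), gives > 100000 nM, a limit of the assay.
Compound 2 `COc1ccc(N(C)c2ncnc3c2ncn3Cc2ccc(OC)c(OC)c2)cc1` gives > 100000 nM, again a limit of the assay.
Compound 3 `COc1ccc(Cn2cnc3c(N(C)c4ccc(OC)cc4)nc(Cl)nc32)cc1` gives > 100000 nM, also a limit of the assay.

Compound 2 differs from compound 1 by methoxy in place of hydrogen on an aromatic carbon. The step that the two limits leave unreadable from compound 1 to compound 2 cannot be read because both values sit at the limit of > 100000 nM in this assay, at which 3 of the 3 values shown sit. The core of compound 3 differs from that of compound 1 by chloro in place of hydrogen on an aromatic carbon, and the step that the two limits leave unreadable from compound 1 to compound 3 is unreadable for the same reason, since the limit of > 100000 nM in this assay, at which 3 of the 3 values shown sit, holds for every value seen so far.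

Compound 4 `COc1ccc(N(C)c2nc(Cl)nc3c2ncn3Cc2ccc(OC)c(OC)c2)cc1` has not been measured. It differs from compound 3 by methoxy in place of hydrogen on an aromatic carbon, the same change as that from compound 1 to compound 2. The expected step of a number no higher from compound 3 to compound 4 (the limit leaves the size open) rests on the fact that compound 1, compound 2 and compound 3 all sit at the limit of > 100000 nM in this assay, at which 3 of the 3 values shown sit, so nothing indicates that adding the methoxy group brings growth inhibition into the measurable range. Compound 4 is therefore expected to give about 100000 nM in this assay, most probably reported again as a limit.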

Compound 4, concentration for 50% growth inhibition: 27000 nM
Beside the measured number, compound 4's estimate is 3.7-fold (0.57 log units) above it; measured number below the stated range.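

In this assay, methoxy in place of hydrogen on an aromatic carbon gives an at least 3.7-fold lower number from compound 3 to compound 4 (0.56 log units; beyond the scatter), and chloro in place of hydrogen on an aromatic carbon gives an at least 3.7-fold lower number from compound 2 to compound 4 (0.56 log units; beyond the scatter). Of the compounds shown, only compound 4, which carries both groups, gives a measured number, 27000 nM, so the methoxy change can be read on the core of compound 3. This does not show that the change carries over from one core to another, since neither step from compound 1 can be read, and the result cannot say how the methoxy step on the core of compound 1 compares with the one on the core of compound 3: the limit of > 100000 nM in this assay, at which 3 of the 4 values shown sit.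

The compounds shown leave open whether an amine in place of the chloro group, or an ethoxy group in place of the added methoxy, would keep, raise or lower the growth inhibition seen with compound 4. On these data alone, the full size of both new steps also stays open, as each starts from a limit.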